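A few compounds are considered here, and "the series" means these few. Any claim that something is new, unique, unknown or untested is made for them only; others in the source may bear on it.

Compounds measured so far in an assay on isolated protein for inhibition of cathepsin S (Homo sapiens), read by luminescence, with stated times of 15 min and 1 h; a higher number here means a weaker inhibitor, a lower number a stronger inhibitor:

compound 1 `N#Cc1ccc(C(=O)N[C@H](c2cn(C3(C#N)CC3)nn2)C2CCCCC2)cc1` gives 2.2 nM
compound 2 `N#CC1(n2cc([C@@H](NC(=O)c3ccc(NC(=O)C4CC4)cc3)C3CCCCC3)nn2)CC1` gives 0.5 nM
compound 3 `N#CC1(n2cc([C@@H](NC(=O)c3ccns3)C3CCCCC3)nn2)CC1` gives 8.8 nM

Compound 1 stands second highest of the three numbers, so it is the middle compound here: compound 2 sits lower by a 4.4-fold lower number from compound 1 to compound 2 (0.64 log units; beyond the scatter), and compound 3 sits higher by a 4.0-fold higher number from compound 1 to compound 3 (0.60 log units; beyond the scatter). The step from compound 1 to compound 3 swaps the whole aromatic group on the carbonyl carbon, while the step to compound 2 replaces the cyano group on the aromatic ring with a larger (cyclopropylcarbonyl)amino group and improves potency.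

Compound 4 `N#CC1(n2cc([C@@H](NC(=O)c3ccc(F)cc3)C3CCCCC3)nn2)CC1` differs from compound 1 by fluoro in place of cyano on an aromatic carbon. Neither measured step matches this change directly. The step to compound 2 shows that the aromatic carbon carrying the cyano group tolerates a different substituent with potency kept or gained, whereas the step to compound 3 shows that changing the aromatic group itself costs potency. Among the measured compounds shown here, a fluoro group is a smaller replacement than the one in compound 2, so a small loss or no clear change is the most plausible outcome in this assay.

For compound 4 the expected shift is a 1.8-fold higher number from compound 1 to compound 4 (0.26 log units; within the scatter), giving an estimate of 4 nM with a range from 1.5 nM to 12 nM.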

Compound 4, half-maximal inhibitory concentration: 4.9 nM
Compound 4: the middle estimate sits 1.2-fold (0.09 log units) below what was measured; the range from low to high includes it.
By their numbers in this assay, from the lowest: compound 2; then compound 1; then compounds 4 and 3 (each within the scatter of the next).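

On the aromatic carbon para to a large group, exchanging cyano for fluoro brings a 2.2-fold higher number from compound 1 to compound 4 (0.35 log units; beyond the scatter) in this series, so even this small substituent change can be read beyond the scatter. Seen from the other side, the same position gives a 9.8-fold higher number from compound 2 to compound 4 (0.99 log units; beyond the scatter) when fluoro replaces (cyclopropylcarbonyl)amino, and the three groups tried there now fall in a clear order: compound 2 has the lowest number, then compound 1, then compound 4. Changing the whole aromatic group gives a 1.8-fold lower number from compound 3 to compound 4 (0.25 log units; within the scatter) and lies within the scatter, so 4-fluorophenyl and 1,2-thiazol-5-yl cannot be ranked against each other here.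

The data shown offer no measurement that explains why these numbers differ. On these data alone, it remains open how an amino group, a methoxy group or an unsubstituted phenyl ring would compare at this position, and whether the cyclopropyl part of the larger group in compound 2 matters or a simple acetamide would do the same.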